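The source may hold more compounds than are shown below. What is called first, only, known or untested is meant among the compounds shown, and "the series" means these compounds.

Going by the values given here, compound 1, with the structure `Oc1nc(NCc2ccccc2)nc2ccc(Cl)cc12`, stands highest of the two numbers measured so far: in a functional assay on the whole organism (uterus) with Rattus norvegicus as the target, tested at 50 uM (on this read-out higher numbers stand for a weaker effect at the one concentration tested and lower numbers for a stronger effect), compound 1 gives 98.1%. Its nearest neighbour is compound 2, `C[C@@H](Nc1nc(O)c2cc(Cl)ccc2n1)c1ccccc1`, which in this assay gives 46.5%. Among the compounds with values here, the single measured step, a number 51.6 percentage points lower from compound 1 to compound 2 (beyond the scatter), comes from a methyl in place of hydrogen on a saturated chain carbon bound to an aromatic carbon and a nitrogen on an aromatic ring. It is a large step, well beyond the scatter, but it touches a different place on the shared core than the change now in question.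

Compound 3, `Oc1nc(NCc2ccccc2)nc2ccc(I)cc12`, differs from compound 1 in one place only: iodo in place of chloro on an aromatic carbon. Within the data shown here, the only measured step concerns the saturated chain carbon, not the aromatic carbon of the fused six-membered ring, so nothing measured here shows how swapping chloro for iodo at that place moves this assay. Among the measured compounds shown here, with no step bearing on it, the expectation is a step of no size beyond the scatter: a number 6.1 percentage points lower from compound 1 to compound 3 (within the scatter) is the estimated change. Compound 3 is therefore expected to give about 92%, in a range from 65% to 100%.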

Compound 3, a percentage reported as activity, at one concentration (the size of the read-out at that concentration, not a potency): 106%
Compound 3: middle estimate off by 14 percentage points, on the low side, outside the stated range (above it).
By their numbers in this assay, from the lowest: compound 2; then compounds 1 and 3 (each within the scatter of the next).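

Going by these compounds alone, changing chloro to iodo gives the first measured step at this aromatic carbon: in this assay the change produces a number 7.9 percentage points higher from compound 1 to compound 3 (within the scatter) and so leaves compound 1 and compound 3 indistinguishable on this read-out. At this place, then, a chlorine and an iodine, each a single heavy atom with no hydrogen-bond donors or acceptors, can be exchanged without a measurable shift, unlike the large step seen earlier when a methyl was added on the saturated chain carbon. Nothing available here explains why the read-out holds across this exchange.

This one exchange of one halogen for another says little about groups of a different kind, so an amine or a carboxylic acid on the same aromatic carbon could still move the read-out in either direction. On these data alone, it also remains open whether the methyl on the saturated chain carbon would produce a step of similar size when iodo, rather than chloro, sits on the aromatic carbon.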